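Replacing a Propyl Chain with a Fluorophenyl Ring

The compounds below may be only part of what the source reports. "The series", "measured", "known", "first", "only" and "open" are said of these compounds alone.

Three compounds share one core, and each was tested in a functional assay for inhibition of sodium/hydrogen exchanger (Oryctolagus cuniculus); on this read-out higher numbers stand for weaker inhibition and lower numbers for stronger inhibition. Compound 1 `Cc1c(C(=O)N=C(N)N)cc(S(C)(=O)=O)c(Cl)c1Cl` gives 29 nM. Compound 2 `CCN(CC)Cc1cc(Br)c(S(C)(=O)=O)cc1C(=O)N=C(N)N` gives 9500 nM. Compound 3 `CCCc1cc(C)c(C(=O)N=C(N)N)cc1S(C)(=O)=O` gives 5.7 nM, the lowest of the three numbers and, since its gaps to both others lie beyond the scatter, the strongest inhibitor among them; compound 1 is its nearest neighbour.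

Compound 4 `Cc1cc(-c2ccc(F)cc2)c(S(C)(=O)=O)cc1C(=O)N=C(N)N` has not yet been measured. It differs from compound 3 by 4-fluorophenyl in place of propyl on an aromatic carbon. Going by the values given here, no pair of measured compounds differs in one place only, so this step has no direct precedent here. For compound 4 a modest move toward weaker inhibition is expected, a step of a 3.5-fold higher number from compound 3 to compound 4 (0.55 log units; beyond the scatter). Compound 4 is therefore estimated at 20 nM, within a range from 4 nM to 100 nM.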

Compound 4, half-maximal inhibitory concentration: 36 nM
Estimate against measurement, compound 4: 1.8-fold (0.26 log units) below, and the stated range covers the measured number.
By their numbers in this assay, from the lowest: compound 3; then compounds 1 and 4 (each within the scatter of the next); then compound 2.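

In this assay, swapping propyl for 4-fluorophenyl on this aromatic carbon gives a 6.3-fold higher number from compound 3 to compound 4 (0.80 log units; beyond the scatter) and so weakens inhibition modestly. This position therefore accepts a larger group carrying an aromatic ring, and compound 4 still gives 36 nM as a measured value, although the propyl chain of compound 3 is the better of these two groups. Still open, going by these compounds, is how an unsubstituted phenyl ring, a butyl chain or an amine on this carbon would compare, and so whether the fluorine matters at all. Nothing available here explains why the ring gives weaker inhibition than the chain.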